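The source may report more compounds than this note shows. Statements on the series, on what has been measured and on what is new or still open speak of the compounds shown alone.

Measured in a functional assay on Huh-7 cells (Homo sapiens) for inhibition, read by MTT assay, with a stated time of 48 h; a higher number here means a weaker inhibitor, a lower number a stronger inhibitor:
- compound 1 `O=C(/C=C/c1coc2cc(O)ccc2c1=O)NCc1ccccc1`: 4690 nM
- compound 2 `COc1ccc2c(=O)c(/C=C/C(=O)NCc3ccccc3)coc2c1`: 13600 nM
- compound 3 `O=C(/C=C/c1coc2cc(O)ccc2c1=O)Nc1ccccc1`: 3880 nM

Compound 1 stands level with compound 3, the gap being a 1.2-fold lower number from compound 1 to compound 3 (0.08 log units; within the scatter), while compound 2 stands apart at a 2.9-fold higher number from compound 1 to compound 2 (0.46 log units; beyond the scatter).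

Compound 4 `O=C(/C=C/c1coc2cc(O)ccc2c1=O)NCc1ccc(F)cc1F` keeps the core of compound 1 and differs as follows: 2,4-difluorophenyl in place of phenyl on a saturated chain carbon bound to an amide-type nitrogen. In short, 2,4-difluorophenyl replaces phenyl on a saturated chain carbon bound to an amide-type nitrogen.

The closest guide is the other change on the amide side, phenyl in place of benzyl on an amide-type nitrogen, which gave a 1.2-fold lower number from compound 1 to compound 3 (0.08 log units; within the scatter). The methyl in place of hydrogen on an oxygen on an aromatic ring, which gave a 2.9-fold higher number from compound 1 to compound 2 (0.46 log units; beyond the scatter), lies elsewhere and is absent from compound 4. Within the data shown here, no measured compound here carries fluorine, so the direction remains weakly supported.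

Little change is therefore expected in this assay, and no step beyond the scatter is anticipated. The estimated step is a 1.3-fold lower number from compound 1 to compound 4 (0.13 log units; within the scatter). The estimate for compound 4 is 3500 nM, with an expected range of 1500 nM to 8000 nM.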

Compound 4, half-maximal inhibitory concentration: > 100000 nM
Compound 4: a limit, no number; the forecaster's own chance of this, stated with the estimate: 3%; at least 28-fold (1.45 log units) between middle value and limit.
By their numbers in this assay, from the lowest: compounds 3 and 1 (each within the scatter of the next); then compound 2. At a limit, above all of these: compound 4.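

In this assay, among these compounds, the aromatic ring on the amide side proves far more sensitive than the earlier compounds indicated, as 2,4-difluorophenyl in place of phenyl gives an at least 21-fold higher number from compound 1 to compound 4 (1.32 log units; beyond the scatter). From the compounds shown here alone, the reading for compound 4 is a limit and not a number, so the true size of this step remains unknown: the limit of > 100000 nM in this assay, at which 1 of the 4 values shown sits. Even so, this step exceeds the methyl change on the aromatic oxygen, a 2.9-fold higher number from compound 1 to compound 2 (0.46 log units; beyond the scatter), and contrasts with the change from benzyl to phenyl, a 1.2-fold lower number from compound 1 to compound 3 (0.08 log units; within the scatter), which stayed within the scatter.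

The compounds shown leave open whether both fluorines are needed for this loss, or whether a single fluorine would have the same result. Going by these compounds, it also remains open how a chlorine, a methoxy group or an amine on that phenyl ring would read.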